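The source may report more compounds than this note shows. Statements on the series, on what has been measured and on what is new or still open speak of the compounds shown alone.

Measured so far in a functional assay on the whole organism for positive allosteric modulation, with Mus musculus as the target; a higher number here means that more compound is needed for the effect, a lower number that less compound is needed:
- compound 1 `CCC(=O)N(c1cccc(F)c1)C1CCCC1N(C)C`: 5 mg/kg
- compound 2 `CCC(=O)N(c1ccccc1Cl)C1CCCC1N(C)C`: > 50 mg/kg

For the measured compounds named here, compound 1 holds the only true number so far (5 mg/kg). Compound 2 stands at > 50 mg/kg, and this reading is a limit of the assay, not a number.

Compound 3 `CCC(=O)N(c1cccc(C(F)(F)F)c1)C1CCCC1N(C)C` has not yet been measured. It differs from compound 1 in one place: trifluoromethyl in place of fluoro on an aromatic carbon, meta to a large group (trifluoromethyl in place of fluoro on an aromatic carbon). The rest of the core of compound 1 stays as it is.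

Going by the values given here, no measured step covers this exchange, or any other single change. The expectation therefore rests only on compound 1 (5 mg/kg) and on the structural change itself. In this assay a small step is expected, towards more compound being needed, and it may well stay within the usual scatter. Among the compounds with values here, the estimated step of a 1.6-fold higher number from compound 1 to compound 3 (0.20 log units; within the scatter) carries wide margins, as no measured step supports it. For compound 3 the expected dose is estimated at 8 mg/kg, with a range of 3 mg/kg to 30 mg/kg.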

Compound 3, dose for half-maximal effect: 0.9 mg/kg
Compound 3: the middle estimate sits 8.9-fold (0.95 log units) above what was measured, and the stated range ends above it.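

In this assay, for the compounds shown here, trifluoromethyl in place of fluoro on an aromatic carbon, meta to a large group, gives a 5.6-fold lower number from compound 1 to compound 3 (0.74 log units; beyond the scatter), the first single change that can be read. Going by these compounds alone, the step shows that the effect at this place on the ring depends on the group it carries, which no earlier pair could show. It also shows that the entering group, with 4 heavy atoms against 1 for fluoro, goes with less compound being needed for the effect, while the rest of the core of compound 1 stays as it is; nothing at hand accounts for this step.

The compounds shown leave open how other groups at this same place would read, such as a nitrile, a methoxy group or an ethyl chain, so one exchange cannot yet be extended into a trend across substituents. They also leave open how the rest of the shared core contributes with trifluoromethyl kept in place, for example with a longer chain on the carbonyl or with a primary amine in place of the dimethylamino group.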